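The source may hold more compounds than are shown below. What is called first, only, known or untested is meant among the compounds shown, and "the series" means these compounds.

In a functional assay on HepG2 cells (Homo sapiens) for inhibition, read by MTT assay, with a stated time of 72 h (on this read-out higher numbers stand for weaker inhibition and lower numbers for stronger inhibition), compound 1 `COc1ccc(/C=C/C(=O)c2c(OC)cc(O)c(CC=C(C)C)c2O)cc1` gives 32400 nM, compound 2 `COc1cc(/C=C/C(=O)c2c(OC)cc(O)c(CC=C(C)C)c2O)ccc1O` gives 21700 nM and compound 3 `COc1cc(O)c(CC=C(C)C)c(O)c1C(=O)/C=C/c1ccc(Cl)cc1` gives 10100 nM, the lowest of the three numbers. Compound 4 `COc1cc(O)c(CC=C(C)C)c(O)c1C(=O)/C=C/c1cccc([N+](=O)[O-])c1` has 3-nitrophenyl in place of 4-chlorophenyl on a double-bonded chain carbon bound to a double-bonded chain carbon. The steps that change the group at this place are a 3.2-fold lower number from compound 1 to compound 3 (0.51 log units; beyond the scatter) and a 2.1-fold lower number from compound 2 to compound 3 (0.33 log units; beyond the scatter), both modest, and a 1.5-fold lower number from compound 1 to compound 2 (0.17 log units; within the scatter), which stays within the scatter. Among the measured compounds shown here, no measured compound carries a nitro group. Since compound 3 already stands lowest at 10100 nM, a small move toward a higher number in this assay is expected. The estimated step is a 1.5-fold higher number from compound 3 to compound 4 (0.17 log units; within the scatter). For compound 4 the expected value is 15000 nM, with an estimated range of 6000 nM to 35000 nM.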

Compound 4, half-maximal inhibitory concentration: 16600 nM
For compound 4 the middle estimate is 1.1-fold (0.04 log units) below the measured one; the measured number falls inside the stated range.
By their numbers in this assay, from the lowest: compounds 3, 4, 2 and 1 (each within the scatter of the next, the first and the last beyond it).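

In this assay, among the compounds shown here, the 3-nitrophenyl group of compound 4 brings the first nitro group to this place, yet the steps of a 1.6-fold higher number from compound 3 to compound 4 (0.22 log units; within the scatter) and a 1.3-fold lower number from compound 2 to compound 4 (0.12 log units; within the scatter) and a 2.0-fold lower number from compound 1 to compound 4 (0.29 log units; within the scatter) all lie within the scatter. Compound 4 therefore cannot be told apart from any of the other three compounds, although compound 3 stands beyond the scatter from both compound 1 and compound 2.

Nothing available explains these numbers. From the compounds shown here alone, whether a phenyl group carrying an amine or a carboxylic acid at this place would separate from these compounds stays open.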